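The source may hold more compounds than are shown below. What is called first, only, known or untested is meant among the compounds shown, and "the series" means these compounds.

Measured compounds:

compound 1 `CN1CCN(CCCCCCn2c3c(c4ccccc42)C(=O)c2c[n+]([O-])c4ccccc4c2C3=O)CC1`, 3800 nM in a toxicity assay on L02 cells (Homo sapiens) for cytotoxicity, read by MTT assay, with a stated time of 72 h; on this read-out lower numbers stand for stronger inhibition and higher numbers for weaker inhibition
compound 2 `CN1CCN(CCCCCn2c3c(c4ccccc42)C(=O)c2c[n+]([O-])c4ccccc4c2C3=O)CC1`, 1640 nM
compound 3 `CN1CCN(CCCn2c3c(c4ccccc42)C(=O)c2c[n+]([O-])c4ccccc4c2C3=O)CC1`, 230 nM

Compound 1 gives the highest number of the three. Its nearest neighbour is compound 2, with a 2.3-fold lower number from compound 1 to compound 2 (0.36 log units; beyond the scatter); the furthest is compound 3, with a 17-fold lower number from compound 1 to compound 3 (1.22 log units; beyond the scatter). The remaining step, a 7.1-fold lower number from compound 2 to compound 3 (0.85 log units; beyond the scatter), points the same way: each time the 4-methylpiperazin-1-yl group sits fewer bonds along the chain from the aromatic nitrogen, the number in this assay falls.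

Compound 4 `O=C1c2c[n+]([O-])c3ccccc3c2C(=O)c2c1c1ccccc1n2CCCN1CCC(O)CC1` is not yet measured. It differs from compound 1 as 4-hydroxypiperidin-1-yl in place of 3-(4-methylpiperazin-1-yl)propyl on a saturated chain carbon, three bonds along the chain from an aromatic nitrogen. Two things happen at once: the place of the basic ring matches compound 3, and the ring itself changes from 4-methylpiperazin-1-yl to 4-hydroxypiperidin-1-yl. For the measured compounds named here, the first part has the measured precedent of compound 1 to compound 3; the ring swap has no measured counterpart, so its own contribution is unknown. The step of a 17-fold lower number from compound 1 to compound 3 (1.22 log units; beyond the scatter) is expected to dominate, giving a large lower number for compound 4, estimated as a 12-fold lower number from compound 1 to compound 4 (1.07 log units; beyond the scatter). Compound 4 is therefore expected at 320 nM, with a range of 100 nM to 1200 nM.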

Compound 4, half-maximal inhibitory concentration: 120 nM
Beside the measured number, compound 4's estimate is 2.7-fold (0.43 log units) above it; low and high end bracket the measured number.
By their numbers in this assay, from the lowest: compounds 4 and 3 (each within the scatter of the next); then compound 2; then compound 1.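

In this assay, the swap to 4-hydroxypiperidin-1-yl from 4-methylpiperazin-1-yl, on a saturated chain carbon, three bonds along the chain from an aromatic nitrogen, can now be read alone, and it stays within the scatter: a 1.9-fold lower number from compound 3 to compound 4 (0.28 log units; within the scatter). The large falls from the two longer-chain compounds also appear with the new ring in place, as a 32-fold lower number from compound 1 to compound 4 (1.50 log units; beyond the scatter) and a 14-fold lower number from compound 2 to compound 4 (1.14 log units; beyond the scatter). Nothing available explains any of these steps.

Still open, on these data alone, is what a plain piperidin-1-yl or a morpholin-4-yl group would give at this place, which would show whether the hydroxyl group itself contributes. Also open, as far as these compounds go, is whether 4-hydroxypiperidin-1-yl on a longer chain would follow the rise seen with 4-methylpiperazin-1-yl.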